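Pyrrolyl Ketone Replaces Fluorophenyl in an Enone Series

The source may hold more compounds than are shown below. What is called first, only, known or untested is meant among the compounds shown, and "the series" means these compounds.

Measured compounds:
Compound 1, `COc1ccc(-c2cc3ccccc3nc2/C=C/C(=O)c2ccc(F)cc2)cc1`: 8320 nM
Compound 2, `COc1ccc(-c2cc3ccccc3nc2/C=C/C(=O)c2c(OC)cccc2OC)cc1`: 7410 nM
Compound 3, `COc1ccc(-c2cc3ccccc3nc2/C=C/C(=O)c2ccc(N)cc2)cc1`: 7530 nM

Of the compounds shown here, three sharing the core of compound 1 have been tested in a functional assay on A549 cells (Homo sapiens) for antiproliferative activity, read by XTT assay, with a stated time of 72 h; on this read-out lower numbers stand for stronger inhibition and higher numbers for weaker inhibition. Compound 1 gives the highest of the three numbers, though both neighbours sit within the scatter of it: the step of a 1.1-fold lower number from compound 1 to compound 2 (0.05 log units; within the scatter) and the step of a 1.1-fold lower number from compound 1 to compound 3 (0.04 log units; within the scatter) are each too small to count, as is the step of a 1.0-fold higher number from compound 2 to compound 3 (0.01 log units; within the scatter). Across these three, exchanging the group on the carbonyl carbon has left the read-out where it was.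

Compound 4, `COc1ccc(-c2cc3ccccc3nc2/C=C/C(=O)c2ccc[nH]2)cc1`, has not yet been measured in this assay. It differs from compound 1 in one place: 1H-pyrrol-2-yl in place of 4-fluorophenyl on a carbonyl carbon. The two steps from compound 1 that bear on this change, the step of a 1.1-fold lower number from compound 1 to compound 2 (0.05 log units; within the scatter) and the step of a 1.1-fold lower number from compound 1 to compound 3 (0.04 log units; within the scatter), both alter the group on the same carbonyl carbon and both stay within the scatter. Within the data shown here, no measured step tells how a five-membered ring with one hetero atom in this position behaves, so the expectation rests on these two.

On that basis the step of a 1.1-fold lower number from compound 1 to compound 4 (0.05 log units; within the scatter) is expected to lie within the scatter. Compound 4 is therefore estimated at 7500 nM, with a range from 3000 nM to 19000 nM.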

Compound 4, half-maximal inhibitory concentration: > 10000 nM
Compound 4: only a limit was reported (the forecaster's own chance of this, stated with the estimate: 10%); middle value at least 1.3-fold (0.12 log units) away from the limit.
By their numbers in this assay, from the lowest: compounds 2, 3 and 1 (each within the scatter of the next). At a limit, above all of these: compound 4.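

In this assay, compound 4 gives only a limit of the assay, not a number: the limit of > 10000 nM in this assay, at which 1 of the 4 values shown sits. The record therefore holds an at least 1.2-fold higher number from compound 1 to compound 4 (0.07 log units; that floor lies within the scatter), an at least 1.3-fold higher number from compound 3 to compound 4 (0.12 log units; that floor lies within the scatter) and an at least 1.3-fold higher number from compound 2 to compound 4 (0.13 log units; that floor lies within the scatter), and although each floor lies within the scatter, the true number of compound 4 could lie further out. Among these compounds, this is the first group at this carbonyl carbon to reach the limit: the 4-fluorophenyl, 2,6-dimethoxyphenyl and 4-aminophenyl groups all gave numbers within the scatter of one another, so the 1H-pyrrol-2-yl group hints that the position may not tolerate every exchange, but it does not establish a real change.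

The compounds shown leave open where the number of compound 4 actually lies, and so whether this exchange matters at all. They also leave open what a furan ring, a thiophene ring or a pyrrole ring with a methyl group on its nitrogen would give on the same carbonyl carbon, which would show whether the ring size, the ring nitrogen or its hydrogen goes with the result.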